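This account rests on a few compounds, and the source may have more. Where it says the series, first, only, none or still open, it means among the compounds named here.

The series is built around a shared enone core. Compound 1, `COc1ccc(/C=C/C(=O)c2cccc(N=[N+]=[N-])c2)cc1O`, carries an azide on its aryl ring and in a functional assay on RAW264.7 cells (Mus musculus) for inhibition, with a stated time of 4 days (on this read-out higher numbers stand for weaker inhibition and lower numbers for stronger inhibition), compound 1 gives 1960 nM. Compound 2, `COc1cc(/C=C/C(=O)c2cccc(-n3cc(C(C)(C)O)nn3)c2)ccc1O`, bears a triazole with a 1-hydroxy-1-methylethyl group, and in this assay compound 2 gives 19800 nM, the highest number among the three measured compounds; its gap to compound 1 lies beyond the scatter, while compound 3, `COc1cc(/C=C/C(=O)c2cccc(-n3cc(-c4ccccc4)nn3)c2)ccc1O`, with a phenyl on the triazole, sits nearest and in this assay compound 3 gives 16800 nM.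

Compound 4, `COc1cc(/C=C/C(=O)c2cccc(-n3cc(-c4ccc(F)cc4)nn3)c2)ccc1O`, is the next member. Relative to compound 2 the change is 4-fluorophenyl in place of 1-hydroxy-1-methylethyl on an aromatic carbon: the group that leaves is 1-hydroxy-1-methylethyl, and the group that enters is 4-fluorophenyl, one six-membered aromatic ring of carbon only, placed on an aromatic carbon of the five-membered aromatic ring with three nitrogens.

For the measured compounds named here, the one measured step that bears on this is a 1.2-fold lower number from compound 2 to compound 3 (0.07 log units; within the scatter), where phenyl replaced the same group at the same place. A fluorine on that phenyl is a small further change, so the step of a 1.3-fold lower number from compound 2 to compound 4 (0.12 log units; within the scatter) is expected to stay within the scatter. Compound 4 is therefore estimated at 15000 nM, with a range of 6000 nM to 40000 nM.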

Compound 4, half-maximal inhibitory concentration: 6450 nM
For compound 4 the middle estimate is 2.3-fold (0.37 log units) above the measured one, within the range that was stated.
By their numbers in this assay, from the lowest: compound 1; then compound 4; then compounds 3 and 2 (each within the scatter of the next).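

The earlier pair gave no sign that this carbon of the five-membered aromatic ring responds to its substituent, as phenyl in place of 1-hydroxy-1-methylethyl stayed within the scatter. With 4-fluorophenyl as the entering group, a 3.1-fold lower number from compound 2 to compound 4 (0.49 log units; beyond the scatter) in this assay is a modest change beyond the scatter, so this place can separate these groups after all. The new comparison of the two aryl compounds isolates the fluoro in place of hydrogen on the phenyl ring, and a 2.6-fold lower number from compound 3 to compound 4 (0.42 log units; beyond the scatter) shows that this single atom change accounts for a shift beyond the scatter, while no measurement shown explains that shift.

The compounds shown leave open whether this step belongs to fluorine alone or would also appear with a chlorine, a methoxy group or an amine in its place on the phenyl ring. For the compounds shown here, they also leave open whether the step would hold on another aryl group, as the fluoro change rests on the single pair of compound 3 and compound 4.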